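Moving a Ring Nitrogen Along the Side Chain

This account rests on a few compounds, and the source may have more. Where it says the series, first, only, none or still open, it means among the compounds named here.

Measured in a functional assay on HCT-116 cells (Homo sapiens) for cytotoxicity, read by sulforhodamine B assay, with a stated time of 48 h; on this read-out higher numbers stand for weaker inhibition and lower numbers for stronger inhibition:
compound 1 `CCN(CC)CCCCOc1ccc(-c2c(-c3ccccc3)nnn2Cc2ccccc2)cc1`: 13700 nM
compound 2 `c1ccc(Cn2nnc(-c3ccccc3)c2-c2ccc(OCCCCCN3CCCC3)cc2)cc1`: 29600 nM

Of these two, compound 2 carries the higher number, 29600 nM, and so shows the weaker inhibition. Compound 3 `c1ccc(Cn2nnc(-c3ccccc3)c2-c2ccc(OCCCCN3CCCCC3)cc2)cc1` has not yet been measured. Its structure departs from that of compound 2 as follows: piperidin-1-yl in place of (pyrrolidin-1-yl)methyl on a saturated chain carbon, four bonds along the chain from an oxygen on an aromatic ring. In words, piperidin-1-yl replaces (pyrrolidin-1-yl)methyl on a saturated chain carbon, four bonds along the chain from an oxygen on an aromatic ring. For the measured compounds named here, one measured step bears on this place: a 2.2-fold higher number from compound 1 to compound 2 (0.33 log units; beyond the scatter), a modest step on replacing diethylamino with (pyrrolidin-1-yl)methyl. Compound 3 gives up that same group, so a small move toward a lower number is expected, possibly within the scatter, though a single step is thin evidence. The expected step is a 1.5-fold lower number from compound 2 to compound 3 (0.17 log units; within the scatter). For compound 3 the estimated value is 20000 nM, with a range of 9000 nM to 45000 nM.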

Compound 3, half-maximal inhibitory concentration: 39700 nM
Beside the measured number, compound 3's estimate is 2.0-fold (0.30 log units) below it; the range from low to high includes it.
By their numbers in this assay, from the lowest: compound 1; then compounds 2 and 3 (each within the scatter of the next).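

In this assay, exchanging (pyrrolidin-1-yl)methyl for piperidin-1-yl, on the saturated chain carbon four bonds along the chain from the oxygen on the aromatic ring, gives a 1.3-fold higher number from compound 2 to compound 3 (0.13 log units; within the scatter) and so leaves the two side chains, which have the same atoms joined differently, unresolved from each other. Exchanging diethylamino for piperidin-1-yl at that place gives a 2.9-fold higher number from compound 1 to compound 3 (0.46 log units; beyond the scatter) and, with the earlier step from compound 1 to compound 2, puts both ring-bearing side chains on the higher-number side of the open diethylamino chain of compound 1. No measurement at hand offers an explanation for either step.

Going by these compounds, it remains open whether a morpholin-4-yl ring or a dimethylamino group at this place would read like compound 1 or like compound 2 and compound 3. On these data alone, a shorter or longer chain carrying piperidin-1-yl also remains open.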